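Replacing 3-(hydroxymethyl)phenyl with 2-methylpyridin-3-yl

The source may report more compounds than this note shows. Statements on the series, on what has been measured and on what is new or still open speak of the compounds shown alone.

For the measured compounds named here, in a physicochemical assay for lipophilicity, read by HPLC, at pH 7.5 (on this read-out lower numbers stand for lower lipophilicity and higher numbers for higher lipophilicity), compound 1 (`CC[C@@H](Nc1c(C#N)c(-c2ccc(-c3cccc(Cl)c3OC)cc2)nc2cnccc12)C(N)=O`) gives 3.1 and compound 2 (`CC[C@@H](Nc1c(C#N)c(-c2ccc(-c3cccc(CO)c3)cc2)nc2cnccc12)C(N)=O`) gives 2 as the lower of the two numbers so far. Compound 3 (`CC[C@@H](Nc1c(C#N)c(-c2ccc(-c3cccnc3C)cc2)nc2cnccc12)C(N)=O`) awaits measurement and carries 2-methylpyridin-3-yl in place of 3-(hydroxymethyl)phenyl on an aromatic carbon, para to a large group (2-methylpyridin-3-yl in place of 3-(hydroxymethyl)phenyl on an aromatic carbon). Going by the values given here, the only measured step bearing on this is the large one a number 1.10 log units lower from compound 1 to compound 2 (beyond the scatter) where 3-(hydroxymethyl)phenyl took the place of 3-chloro-2-methoxyphenyl on an aromatic carbon. Among the compounds with values here, compound 3 gives up that same 3-(hydroxymethyl)phenyl, yet the entering group has no measured counterpart, so with a number 1.10 log units lower from compound 1 to compound 2 (beyond the scatter) as the sole guide only a partial return toward a higher number is expected. In this assay the expected change is a number 0.40 log units higher from compound 2 to compound 3 (beyond the scatter) and remains smaller than that large step. For compound 3 the estimate is 2.4 (expected range 1.9 to 2.9).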

Compound 3, distribution coefficient: 1.9
Compound 3: the middle estimate sits 0.50 log units above what was measured, within the range that was stated.
By their numbers in this assay, from the lowest: compounds 3 and 2 (each within the scatter of the next); then compound 1.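

In this assay, the change on this aromatic carbon, para to a large group, reads a number 0.10 log units lower from compound 2 to compound 3 (within the scatter), so 2-methylpyridin-3-yl and 3-(hydroxymethyl)phenyl cannot be told apart here, although the first has 0 hydrogen-bond donors and the second has 1. Measured against 3-chloro-2-methoxyphenyl, 2-methylpyridin-3-yl gives a number 1.20 log units lower from compound 1 to compound 3 (beyond the scatter), a large step like a number 1.10 log units lower from compound 1 to compound 2 (beyond the scatter), so among these three compounds a hydrogen-bond donor in the entering group is not needed for a large step. Nothing available explains why these two different groups read alike.

The compounds shown leave open how an amine or a carboxylic acid on this outer ring would read, and whether the methyl group or the ring nitrogen of 2-methylpyridin-3-yl accounts for the step from compound 1. They also leave open whether these replacements would read the same with a different group on the shared core.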